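Replacing a Halogenated Benzyl Arm with a Furanylmethyl Arm

This account rests on a few compounds, and the source may have more. Where it says the series, first, only, none or still open, it means among the compounds named here.

Compound 3 `C=C1CC[C@@H]2[C@](C)(CNCc3ccc(Br)cc3)[C@H](O)CC[C@@]2(C)[C@@H]1/C=C/C1=CCOC1=O` carries a 4-bromobenzyl group on its amine. In a functional assay on BMMC cells (Mus musculus, strain C57BL/6) for inhibition, with stated times of 5 days and 48 h (on this read-out lower numbers stand for stronger inhibition and higher numbers for weaker inhibition), compound 3 gives 430 nM. Within the data shown here, that number lies close to the one of compound 2 `C=C1CC[C@@H]2[C@](C)(CNCc3ccc(Cl)cc3)[C@H](O)CC[C@@]2(C)[C@@H]1/C=C/C1=CCOC1=O`, which gives 420 nM, and to the one of compound 1 `C=C1CC[C@@H]2[C@](C)(CNCc3ccc(OC)cc3)[C@H](O)CC[C@@]2(C)[C@@H]1/C=C/C1=CCOC1=O`, which gives 750 nM; the steps of a 1.8-fold lower number from compound 1 to compound 2 (0.25 log units; within the scatter), a 1.7-fold lower number from compound 1 to compound 3 (0.24 log units; within the scatter) and a 1.0-fold higher number from compound 2 to compound 3 (0.01 log units; within the scatter) all stay within the scatter. Compound 4 `C=C1CC[C@@H]2[C@](C)(CNCc3ccco3)[C@H](O)CC[C@@]2(C)[C@@H]1/C=C/C1=CCOC1=O` differs from compound 3 by furan-2-yl in place of 4-bromophenyl on a saturated chain carbon bound to an amine nitrogen. The measured steps only swap one substituent for another on the aromatic ring; none exchanges the ring itself, so they offer no direct guide. Because the step of a 1.7-fold lower number from compound 1 to compound 3 (0.24 log units; within the scatter) stayed within the scatter, a modest step toward a weaker number is expected, a 1.5-fold higher number from compound 3 to compound 4 (0.18 log units; within the scatter). Compound 4 is therefore estimated at 650 nM, ranging from 250 nM to 1700 nM.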

Compound 4, half-maximal inhibitory concentration: 1830 nM
Compound 4: middle estimate off by 2.8-fold (0.45 log units), on the low side; measured number above the stated range.
By their numbers in this assay, from the lowest: compounds 2, 3 and 1 (each within the scatter of the next); then compound 4.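

Exchanging the ring itself on the saturated chain carbon bound to an amine nitrogen shifts the number in this assay as none of the substituent swaps on the ring did, with a 4.3-fold higher number from compound 3 to compound 4 (0.63 log units; beyond the scatter) and a 4.4-fold higher number from compound 2 to compound 4 (0.64 log units; beyond the scatter) and also a 2.4-fold higher number from compound 1 to compound 4 (0.39 log units; beyond the scatter) all beyond the scatter. Furan-2-yl thus gives weaker inhibition than 4-bromophenyl, 4-chlorophenyl and 4-methoxyphenyl alike, so this position responds to the ring and not only to its substituent. No evidence at hand accounts for this shift.

The compounds shown leave open whether the shift follows from the furan ring itself or from the absence of a substituent on the ring. Unsubstituted phenyl and thiophen-2-yl on the same arm would separate these two readings.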